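Swapping a furan ring for a diene chain in an amide

The source may hold more compounds than are shown below. What is called first, only, known or untested is meant among the compounds shown, and "the series" means these compounds.

Compound 1, `CCCCCCCCCCCCCCCCCCNC(=O)[C@@H](N)[C@@H](C)O`, in a functional assay on SiHa cells (Homo sapiens) for cytotoxicity, read by MTT assay, with a stated time of 48 h (on this read-out higher numbers stand for weaker inhibition and lower numbers for stronger inhibition), gives 39500 nM.
Compound 2, `CCCCCCCCNC(=O)[C@@H](NC(=O)c1ccco1)[C@@H](C)O`, in this assay gives 124000 nM.
Compound 3, `CCCCCCCCNC(=O)[C@@H](NC(=O)/C=C/c1ccccc1)[C@@H](C)O`, in this assay gives 41400 nM.

Of the three measured compounds, compound 2 has the highest number, and both other compounds lie beyond the scatter below it; in this assay a higher number means weaker inhibition, so compound 2 is the weakest of the three.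

Compound 4, `C/C=C/C=C/C(=O)N[C@H](C(=O)NCCCCCCCC)[C@@H](C)O`, is not yet measured. It is made from compound 2 by one change: penta-1,3-dien-1-yl in place of furan-2-yl on a carbonyl carbon. Going by the values given here, one measured step bears on this. The step of a 3.0-fold lower number from compound 2 to compound 3 (0.48 log units; beyond the scatter) also replaced the furan-2-yl group on the same carbonyl carbon with an open unsaturated chain, the 2-phenylethenyl group. The penta-1,3-dien-1-yl group is likewise an open chain with double bonds outside aromatic rings, though it carries no ring at all. A drop of similar direction is therefore expected, plausibly somewhat smaller since the aromatic ring of compound 3 is missing; the expected step is a 2.3-fold lower number from compound 2 to compound 4 (0.35 log units; beyond the scatter).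

Compound 4 is thus estimated at 55000 nM in this assay, within a range from 25000 nM to 125000 nM.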

Compound 4, half-maximal inhibitory concentration: 123000 nM
Compound 4: middle estimate off by 2.2-fold (0.35 log units), on the low side; the measured number falls inside the stated range.
By their numbers in this assay, from the lowest: compounds 1 and 3 (each within the scatter of the next); then compounds 4 and 2 (each within the scatter of the next).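

An open unsaturated chain on the carbonyl carbon is not enough on its own: penta-1,3-dien-1-yl in place of furan-2-yl gives a 1.0-fold lower number from compound 2 to compound 4 (0.00 log units; within the scatter) in this assay, so this ringless chain and the furan ring cannot be told apart here. Among these three amides, the lower number therefore goes with the phenyl ring of compound 3, since prop-1-en-1-yl in place of phenyl on a double-bonded chain carbon bound to a double-bonded chain carbon gives a 3.0-fold higher number from compound 3 to compound 4 (0.47 log units; beyond the scatter) and brings the number back up. Nothing measured here explains this difference.

As far as these compounds go, whether phenyl itself matters, or any ring at the end of the chain would serve, remains open, for instance with a pyridine ring or a methoxy-bearing phenyl. Also open, from the compounds shown here alone, is whether the saturated 2-phenylethyl group would match the 2-phenylethenyl group of compound 3.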